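This account rests on a few compounds, and the source may have more. Where it says the series, first, only, none or still open, it means among the compounds named here.

Compound 1 `CNC(=O)c1cc(OCCCCOc2ccc(C(=O)CC(C)(C)C)c(O)c2C)ccc1F`: 164 nM
Compound 2 `Cc1c(OCCCCOc2ccc(C(=O)O)cc2F)ccc(C(=O)CC(C)(C)C)c1O`: 75 nM

Both were tested in an assay for positive allosteric modulation of metabotropic glutamate receptor 2 (Rattus norvegicus); on this read-out lower numbers stand for an effect already at smaller amounts and higher numbers for an effect only at larger amounts of compound. Compound 1 gives 164 nM, the higher of the two numbers, while compound 2 gives 75 nM, a gap beyond the usual scatter. Compound 3 `Cc1c(OCCCCOc2ccc(F)c(C(=O)N(C)C)c2)ccc(C(=O)CC(C)(C)C)c1O` has not been measured. It differs from compound 1 by methyl in place of hydrogen on an amide-type nitrogen. For the measured compounds named here, no measured pair shows this change, so only a modest step is expected, a 1.2-fold higher number from compound 1 to compound 3 (0.09 log units; within the scatter), in either direction and possibly within the scatter. Compound 3 is estimated at 200 nM, with a range from 80 nM to 500 nM.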

Compound 3, half-maximal effective concentration: 3810 nM
Compound 3: the middle estimate sits 19-fold (1.28 log units) below what was measured; measured number outside the range, above it.
By their numbers in this assay, from the lowest: compound 2; then compound 1; then compound 3.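

At this amide-type nitrogen, methyl in place of hydrogen gives a 23-fold higher number from compound 1 to compound 3 (1.37 log units; beyond the scatter) in this assay. For the compounds shown here, one added carbon at this spot is therefore enough to change the read-out strongly, which the earlier compounds could not show, as they contained no pair differing in one place. Nothing at hand says why the step is so large.

Still open, from the compounds shown here alone, is how a primary amide, with two hydrogens on this nitrogen, would compare, and whether an ethyl group on the nitrogen would read like methyl.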